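Shortening the alkene side chain on a brominated core

The source may report more compounds than this note shows. Statements on the series, on what has been measured and on what is new or still open speak of the compounds shown alone.

Measured so far:
Compound 1, `COc1cc(/C=C(\C)C(=O)N2CCC=CC2=O)cc(OC)c1OC`: 11700 nM
Compound 2, `CC/C(=C\c1cc(OC)c(OC)c(OC)c1)C(=O)N1CCC=C(Br)C1=O`: 2120 nM

In a functional assay on MDA-MB-231 cells (Homo sapiens) for cytotoxicity, read by MTT assay, with a stated time of 72 h (a higher number here means a weaker inhibitor, a lower number a stronger inhibitor), compound 2 gives the lowest of the two numbers; compound 1 sits well above it, beyond the usual scatter. Compound 3, `COc1cc(/C=C(\C)C(=O)N2CCC=C(Br)C2=O)cc(OC)c1OC`, keeps the bromine of compound 2 but differs by hydrogen in place of methyl on a saturated chain carbon bound to a double-bonded chain carbon. For the measured compounds named here, no measured pair isolates this change, so its effect is unknown. A small loss of potency, or none beyond the scatter, is expected. Compound 3 is expected to give 3500 nM, with a range from 1200 nM to 10000 nM. The expected step of a 1.7-fold higher number from compound 2 to compound 3 (0.22 log units; within the scatter) is modest.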

Compound 3, half-maximal inhibitory concentration: 2470 nM
Estimate against measurement, compound 3: 1.4-fold (0.15 log units) above; the range from low to high includes it.
By their numbers in this assay, from the lowest: compounds 2 and 3 (each within the scatter of the next); then compound 1.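

In this assay, shortening the side chain from ethyl to methyl makes no difference that can be told apart from the usual scatter, with a 1.2-fold higher number from compound 2 to compound 3 (0.07 log units; within the scatter). For the compounds shown here, compound 3 also gives the first pair that isolates bromo in place of hydrogen on a double-bonded ring carbon, and this step lies beyond the scatter, with a 4.7-fold lower number from compound 1 to compound 3 (0.68 log units; beyond the scatter). Nothing available explains either result. Still open, going by these compounds, is whether a longer chain, such as propyl, would change the number, and whether an amine in place of the bromo group would keep the gain.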